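Trimming the phenoxy group to a hydroxy group

A few compounds are considered here, and "the series" means these few. Any claim that something is new, unique, unknown or untested is made for them only; others in the source may bear on it.

Measured so far in an assay on isolated protein for inhibition of Polyunsaturated fatty acid 5-lipoxygenase (Homo sapiens), read by HPLC, with a stated time of 15 min; a lower number here means a stronger inhibitor, a higher number a weaker inhibitor:
compound 1, `CCCC/C(=C\c1cc(Oc2ccccc2)ccc1OCc1ccc(C(F)(F)F)cc1)C(=O)O`, 2100 nM
compound 2, `CCCC/C(=C\c1cc(OCc2ccc(-c3ccccc3)cc2)ccc1OCc1ccc(C(F)(F)F)cc1)C(=O)O`, "not active" (no number reported)
compound 3, `CCCC/C(=C\c1cc(OCc2ccc(-c3csc(C)n3)cc2)ccc1OCc1ccc(C(F)(F)F)cc1)C(=O)O`, 6700 nM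

Compound 1 holds the lowest of the two numbers reported. The nearest neighbour is compound 3, whose value stands higher, a gap that lies beyond the usual scatter of this assay. Compound 2 carries no number at all; in this assay compound 2 is reported simply as not active.

Compound 4, `CCCC/C(=C\c1cc(O)ccc1OCc1ccc(C(F)(F)F)cc1)C(=O)O`, has not yet been measured. It differs from compound 1 in one place: hydrogen in place of phenyl on an oxygen on an aromatic ring. Put another way, the phenoxy group of compound 1 becomes a hydroxy group in compound 4, while the rest of the shared core is unchanged.

Going by the values given here, no measured pair here differs in exactly this way, so the size of the step can only be guessed from the neighbours. The three measured compounds all carry a larger group at this oxygen, and the smallest of them, compound 1, gives the lowest number, which does not by itself say what happens when the group is removed entirely. A step toward a higher number seems more likely than not, and it may well exceed the scatter. The step from compound 1 to compound 4 is therefore expected to be a 2.9-fold higher number from compound 1 to compound 4 (0.46 log units; beyond the scatter). Compound 4 is estimated at 6000 nM, with a range from 2000 nM to 25000 nM.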

Compound 4, half-maximal inhibitory concentration: "not active" (no number reported)
The entry for compound 4 holds no number, and the estimate cannot be compared.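

In this assay, going by these compounds alone, compound 4 is reported only as not active, with no number, so no step from compound 1 to compound 4 can be read. The compounds shown leave open how large the change from phenoxy to hydroxy is in numbers. Nothing given here offers an explanation for this result.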